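The compounds below may be only part of what the source reports. "The series", "measured", "known", "first", "only" and "open" are said of these compounds alone.

Compounds measured so far:

compound 1, `CCc1ccccc1NC(=O)C1C(C(=O)O)[C@@H]2CC[C@H]1O2` — 10000 nM
compound 2, `CCCNC(=O)C1C(C(=O)O)[C@@H]2CC[C@H]1O2` — 10000 nM
compound 3, `C/C(=N/Nc1ccccc1)c1ccccc1NC(=O)C1C(C(=O)O)[C@@H]2CC[C@H]1O2` — 10000 nM

All three values come from an ADME assay on SW480 cells (Homo sapiens) for cytotoxicity, read by MTT assay, with a stated time of 72 h; a lower number here means a stronger inhibitor of growth, a higher number a weaker inhibitor of growth. In this assay compound 2 gives 10000 nM, compound 1 gives 10000 nM and compound 3 gives 10000 nM. At the digits shown the three numbers are the same, and the gaps between them lie within the usual scatter of repeated measurements, so none of the three can be called stronger or weaker than the others. The three share one core and differ only in the group carried on the amide nitrogen, and that variation has not shifted the number.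

The step now goes from compound 2 to compound 4, `O=C(O)CCCNC(=O)C1C(C(=O)O)[C@@H]2CC[C@H]1O2`. The change is carboxy in place of hydrogen on a saturated chain carbon, three bonds along the chain from an amide-type nitrogen. Going by the values given here, no pair of measured compounds that differ in one place is available, so there is nothing in these numbers from which the size of this step could be read. The expectation rests on the flat picture across compounds 1, 2 and 3: the step from compound 2 to compound 4 is expected to be no change at the digits printed from compound 2 to compound 4 (within the scatter), that is, no change beyond the scatter. Compound 4 is therefore estimated at 10000 nM, with a range from 5000 nM to 20000 nM.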

Compound 4, concentration for 50% growth inhibition: 10000 nM
The estimate for compound 4 equals the measured number at the digits printed; low and high end bracket the measured number.
By their numbers in this assay, from the lowest: compounds 1, 2, 3 and 4 (each within the scatter of the next).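

In this assay, carboxy in place of hydrogen on a saturated chain carbon, three bonds along the chain from an amide-type nitrogen, gives no change at the digits printed from compound 2 to compound 4 (within the scatter) and so leaves the reading where it was. Going by these compounds alone, this is the first pair here that differs in one place, so it gives the first direct reading at this position: going from propyl to 3-carboxypropyl on the amide nitrogen does not shift the number beyond the usual scatter of repeated measurements. The earlier compounds could only show a flat picture across groups that differ in more than one place, and no measurement given here bears on why this step leaves the number unchanged.

All four compounds read the same, so the compounds shown do not yet reveal any change that moves the number in either direction. Going by these compounds, it remains open whether an amine at the end of the same chain, an ester in place of the carboxy group, or a longer chain carrying that carboxy group would read differently from compound 4.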